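The source may report more compounds than this note shows. Statements on the series, on what has been measured and on what is new or still open speak of the compounds shown alone.

In a functional assay on CHO-K1 cells for antagonist activity at transient receptor potential cation channel subfamily V member 1 (Homo sapiens), read by FLIPR (on this read-out lower numbers stand for stronger inhibition and higher numbers for weaker inhibition), compound 1 `CCCN(CCC)c1nc(C(F)(F)F)ccc1CNC(=O)C(C)c1ccc(NS(C)(=O)=O)c(F)c1` gives 0.2 nM. Compound 2 `CC(C(=O)NCc1ccc(C(F)(F)F)nc1N1CCC(=O)CC1)c1ccc(NS(C)(=O)=O)c(F)c1`, which differs from it in one place, gives 91 nM in this assay. For the measured compounds named here, of the two numbers measured, compound 2 therefore stands highest, that is weakest, and the one step that connects them, a 460-fold higher number from compound 1 to compound 2 (2.66 log units; beyond the scatter), shows that what sits on this aromatic carbon of the shared core can move the number a great deal.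

Compound 3 `CC(C)OC1CCN(c2nc(C(F)(F)F)ccc2CNC(=O)C(C)c2ccc(NS(C)(=O)=O)c(F)c2)CC1` keeps the ring placed there but changes what hangs from it: 4-isopropoxypiperidin-1-yl in place of 4-oxopiperidin-1-yl on an aromatic carbon. Going by the values given here, no measured step covers this particular exchange, so only the single step from compound 1 to compound 2 bears on it, and it says that changes at this position are large rather than small. Since that step went upward when the ring with the carbonyl replaced the dipropylamino group, and compound 3 moves away from the carbonyl again, a step back downward, beyond the scatter, is the expected outcome, of a size estimated as a 15-fold lower number from compound 2 to compound 3 (1.18 log units; beyond the scatter). For compound 3 in this assay the estimated value is 6 nM, with a range from 1 nM to 40 nM.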

Compound 3, inhibition constant: 3 nM
The estimate for compound 3 lay 2.0-fold (0.30 log units) above the measured number; the range from low to high includes it.
By their numbers in this assay, from the lowest: compound 1; then compound 3; then compound 2.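

In this assay, keeping the six-membered non-aromatic ring and changing only what hangs from it gives a 30-fold lower number from compound 2 to compound 3 (1.48 log units; beyond the scatter) and so shows that the group carried on the ring, not just the presence of a ring, can move the number a great deal at this position. The dipropylamino group of compound 1 still holds the lowest number of the three, and a 15-fold higher number from compound 1 to compound 3 (1.18 log units; beyond the scatter) shows that 4-isopropoxypiperidin-1-yl recovers much of the ground lost with 4-oxopiperidin-1-yl but does not close the gap. No supporting data are at hand to say why these groups differ as they do.

The compounds shown leave open whether the gain belongs to the ether oxygen or to the isopropyl group on it, which a 4-hydroxypiperidin-1-yl group with its alcohol, a 4-methoxypiperidin-1-yl group or a 4-isopropylpiperidin-1-yl group without the oxygen could help to separate. They also leave open how the number responds to the chains of the open dialkylamino group, for instance whether dibutylamino would sit higher or lower than dipropylamino.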